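Removing the isopropyl from compound 2

The source may hold more compounds than are shown below. What is called first, only, known or untested is meant among the compounds shown, and "the series" means these compounds.

Measured in an ADME assay on Huh-7 cells (Homo sapiens) for cytotoxicity; a higher number here means that more compound is tolerated, a lower number that less compound is tolerated:
- compound 1 `O=C(c1nc2sccn2c1Cl)N1CCN(C2CCCC2)C(=O)C1`: > 10000 nM (a limit, not a number)
- compound 2 `Cc1c(C(C)C)sc2nc(C(=O)N3CCN(C4CCCC4)C(=O)C3)c(Cl)n12`: > 10000 nM (a limit, not a number)

Compound 2 gives no number in this assay, only the limit > 10000 nM. Within the data shown here, both measured compounds share this position, and the series so far is described by the limit of > 10000 nM in this assay, at which 2 of the 2 values shown sit. Among the measured compounds shown here, no size of effect can be read from either result, and no step between measured compounds is available.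

The next compound is compound 3 `Cc1csc2nc(C(=O)N3CCN(C4CCCC4)C(=O)C3)c(Cl)n12`, which has hydrogen in place of isopropyl on an aromatic carbon, next to the ring sulfur (hydrogen in place of isopropyl on an aromatic carbon). The group that leaves sits next to the ring atom that bears a methyl group, and that methyl group stays in compound 3.

The expectation rests on compound 1, whose result is also a limit at > 10000 nM. In this assay no change beyond the usual scatter is expected, with an estimated step that the limit leaves unreadable from compound 2 to compound 3. A further report of only a limit is the likeliest result.

For compound 3 the estimate is 12000 nM, with an expected range of 7000 nM to 25000 nM.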

Compound 3, half-maximal cytotoxic concentration: > 10000 nM
Compound 3 ended at the assay's limit (the forecaster's own chance of this, stated with the estimate: 90%); the middle value does not contradict the limit.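

In this assay, among these compounds, compound 3 gives > 10000 nM, a limit and not a number, so no step from compound 1 or compound 2 to compound 3 can be read. The three compounds share one position: the limit of > 10000 nM in this assay, at which 3 of the 3 values shown sit.

The compounds shown leave open whether the isopropyl or methyl group changes the half-maximal cytotoxic concentration at all.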